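The source may report more compounds than this note shows. Statements on the series, on what has been measured and on what is new or still open speak of the compounds shown alone.

Three compounds share one core, an amide linked through a sulfur-bearing chain to a thiocarbonyl carbon, and differ only in the ring on that carbon. Compound 1 `Nc1ccccc1NC(=O)c1ccc(CSC(=S)N2CCCc3ccccc32)cc1` gives 35.7% in a functional assay on HeLa cells (Homo sapiens) for antiproliferative activity, read by CCK-8 assay, with a stated time of 72 h, tested at 8 uM (a higher number here means a stronger effect of the compound at the concentration tested, a lower number a weaker effect), the lowest of the three numbers. Compound 2 `Nc1ccccc1NC(=O)c1ccc(CSC(=S)N2CCN(c3ccc(F)cc3)CC2)cc1` gives 64.5% and compound 3 `Nc1ccccc1NC(=O)c1ccc(CSC(=S)N2CCN(c3ccccc3F)CC2)cc1` gives 59.2%, both beyond the scatter above compound 1. Within the data shown here, the only measured step, a number 5.3 percentage points lower from compound 2 to compound 3 (within the scatter), concerns the fluorophenyl group and says nothing about the ring on the thiocarbonyl carbon. Compound 4 `Nc1ccccc1NC(=O)c1ccc(CSC(=S)N2CCCC2)cc1` carries the change (pyrrolidin-1-yl in place of 1,2,3,4-tetrahydroquinolin-1-yl on a thiocarbonyl carbon). Among the measured compounds shown here, no measured step covers this exchange, so no shift beyond the scatter is expected, and the estimate for compound 4 is 32% (range 15% to 50%), a step of a number 3.7 percentage points lower from compound 1 to compound 4 (within the scatter).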

Compound 4, a percentage reported as inhibition, at one concentration (the size of the read-out at that concentration, not a potency): 77.8%
Compound 4: the middle estimate sits 45.8 percentage points below what was measured, and the stated range ends below it.
By their numbers in this assay, from the lowest: compound 1; then compounds 3 and 2 (each within the scatter of the next); then compound 4.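

In this assay the exchange gives a number 42.1 percentage points higher from compound 1 to compound 4 (beyond the scatter) and so shows that the group on the thiocarbonyl carbon can strongly change the read-out, which the fluorophenyl step could not show. Here, a single five-membered non-aromatic ring gives a higher number than a group that also carries a six-membered aromatic ring. No supporting evidence bears on why the number rises. From the compounds shown here alone, whether piperidin-1-yl or an open-chain diethylamino group on that carbon would keep this level stays open, as does whether losing the aromatic ring or reducing the group's size matters more.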